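Ester acyl variation at the side-chain oxygen

The source may report more compounds than this note shows. Statements on the series, on what has been measured and on what is new or still open speak of the compounds shown alone.

The series shares the core of compound 1 `CC(C)=CC[C@@H](OC[C@@H](C)O)C1=CC(=O)c2c(O)ccc(O)c2C1=O` and varies the group on the oxygen of the side chain. In a functional assay on HeLa cells (Homo sapiens) for cytotoxicity, read by MTT assay (a higher number here means a weaker inhibitor, a lower number a stronger inhibitor), compound 1 gives 22500 nM. Compound 3 `COCCO[C@H](CC=C(C)C)C1=CC(=O)c2c(O)ccc(O)c2C1=O` carries 2-methoxyethyl there, and in this assay compound 3 gives 62400 nM, a step of a 2.8-fold higher number from compound 1 to compound 3 (0.44 log units; beyond the scatter). Compound 2 `CC(C)=CC[C@@H](OC(=O)C1CCCCO1)C1=CC(=O)c2c(O)ccc(O)c2C1=O` carries an (oxan-2-yl)carbonyl ester. For compound 2 this assay reports only a limit, > 100000 nM. Compound 2 thus stands at the limit, (the limit of > 100000 nM in this assay, at which 1 of the 3 values shown sits), so the step of an at least 4.4-fold higher number from compound 1 to compound 2 (0.64 log units; beyond the scatter) is known only as a floor, as is the step of an at least 1.6-fold lower number from compound 2 to compound 3 (0.20 log units; that floor lies within the scatter).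

Compound 4 `CC(C)=CC[C@@H](OC(=O)CC(O)c1ccccc1)C1=CC(=O)c2c(O)ccc(O)c2C1=O` keeps the ester: 2-hydroxy-2-phenylethyl in place of oxan-2-yl on a carbonyl carbon. Going by the values given here, no measured step compares two esters with each other; the only steps that bear on compound 4 are an at least 4.4-fold higher number from compound 1 to compound 2 (0.64 log units; beyond the scatter) and an at least 1.6-fold lower number from compound 2 to compound 3 (0.20 log units; that floor lies within the scatter), both running from the limit of compound 2. The number for compound 4 is therefore expected near that limit, with a step of a number no higher from compound 2 to compound 4 (the limit leaves the size open) not beyond the scatter, and with a fair chance that this assay again returns only a limit. The estimate for compound 4 is 100000 nM, between 30000 nM and 300000 nM.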

Compound 4, half-maximal inhibitory concentration: 44500 nM
Beside the measured number, compound 4's estimate is 2.2-fold (0.35 log units) above it, and the stated range covers the measured number.
By their numbers in this assay, from the lowest: compounds 1, 4 and 3 (each within the scatter of the next, the first and the last beyond it). At a limit, above all of these: compound 2.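

The ester at the side-chain oxygen is not tied to the limit: in this assay, 2-hydroxy-2-phenylethyl in place of oxan-2-yl on the carbonyl carbon gives an at least 2.2-fold lower number from compound 2 to compound 4 (0.35 log units; beyond the scatter) and returns a measured number. The size of this step is known only as a floor, and the value for compound 2 is a limit of the assay: the limit of > 100000 nM in this assay, at which 1 of the 4 values shown sits. Going by these compounds alone, the position therefore tolerates at least one change in the acyl group that moves the read-out within the ester type, a difference the earlier compounds, with a single ester, could not show.

No ester shown separates the hydroxyl of 2-hydroxy-2-phenylethyl from its phenyl ring, so neither can be credited with the step. An acyl group ending in an amine or a carboxylic acid, or a longer unbranched acyl chain, remains to be placed against compound 4.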